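Aryl ring substituents on the triazole: hydroxy entering

The source may hold more compounds than are shown below. What is called first, only, known or untested is meant among the compounds shown, and "the series" means these compounds.

The series keeps one bicyclic lactam core and varies the aryl group on the triazole nitrogen. Compound 1 `Cc1ccccc1-n1cc(CN2C(=O)C[C@@H]3CC[C@@]2(C)C3(C)C)nn1` gives 150 nM in a functional assay on HepG2 cells (Homo sapiens) for inhibition, read by MTT assay, with a stated time of 24 h; on this read-out lower numbers stand for stronger inhibition and higher numbers for weaker inhibition. Compound 2 `COc1ccc(-n2cc(CN3C(=O)C[C@@H]4CC[C@@]3(C)C4(C)C)nn2)cc1` gives 100 nM in this assay, and compound 3 `CC1(C)[C@H]2CC[C@]1(C)N(Cc1cn(-c3ccccc3)nn1)C(=O)C2` gives 90 nM in this assay. Within the data shown here, compound 3 has the lowest of the three numbers, but its neighbours sit close: a 1.7-fold lower number from compound 1 to compound 3 (0.22 log units; within the scatter) and a 1.1-fold lower number from compound 2 to compound 3 (0.05 log units; within the scatter), so no compound can be separated from another here.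

Compound 4 `CC1(C)[C@H]2CC[C@]1(C)N(Cc1cn(-c3cccc(O)c3)nn1)C(=O)C2` differs from compound 3 by hydroxy in place of hydrogen on an aromatic carbon. The relevant precedent is that changing the substituent on this six-membered aromatic ring of carbon only has so far moved nothing beyond the scatter: a 1.5-fold lower number from compound 1 to compound 2 (0.18 log units; within the scatter), a 1.7-fold lower number from compound 1 to compound 3 (0.22 log units; within the scatter), a 1.1-fold lower number from compound 2 to compound 3 (0.05 log units; within the scatter). Among the measured compounds shown here, the hydroxy group has not yet appeared on this ring, so there is no direct step for it. The expectation is therefore a step of a 1.1-fold higher number from compound 3 to compound 4 (0.02 log units; within the scatter) in this assay, with no clear direction. Compound 4 is expected to give 95 nM, in the range 45 nM to 200 nM.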

Compound 4, half-maximal inhibitory concentration: 70 nM
The estimate for compound 4 lay 1.4-fold (0.13 log units) above the measured number, within the range that was stated.
By their numbers in this assay, from the lowest: compounds 4, 3, 2 and 1 (each within the scatter of the next, the first and the last beyond it).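

Among the aryl substituents shown, only hydroxy carries a hydrogen-bond donor, and at this place, meta to a large group, it is accommodated in this assay without a separable change: a 1.3-fold lower number from compound 3 to compound 4 (0.11 log units; within the scatter) and a 1.4-fold lower number from compound 2 to compound 4 (0.15 log units; within the scatter) both stay within the scatter. Among these compounds, the only pair to separate is a 2.1-fold lower number from compound 1 to compound 4 (0.33 log units; beyond the scatter), a modest step beyond the scatter, but it exchanges 2-methylphenyl for 3-hydroxyphenyl and so does not isolate the hydroxy group. No supporting measurement bears on this result.

From the compounds shown here alone, whether the hydroxy hydrogen contributes anything remains open, and a methoxy group at this same place would address that directly. Also open, going by these compounds, is whether this place accepts an amine or a carboxylic acid with a similarly small step.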